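The compounds below may be only part of what the source reports. "The series", "measured", "known", "first", "only" and "open" are said of these compounds alone.

In a functional assay on U-87MG ATCC cells (Homo sapiens) for cytotoxicity, read by resazurin assay, with a stated time of 48 h (on this read-out lower numbers stand for stronger inhibition and higher numbers for weaker inhibition), compound 1 (`COc1ccc(/C=C2\CS(=O)(=O)C/C(=C\c3ccc(OC)cc3)C2=O)cc1`) gives 3570 nM and compound 2 (`O=C1/C(=C/c2ccc(O)cc2)CS(=O)(=O)C/C1=C\c1ccc([N+](=O)[O-])cc1`) gives 2170 nM. For the measured compounds named here, compound 2 thus holds the lower of only two numbers, but the two values lie within the usual scatter of each other, so the measurements do not separate these compounds. Compound 3 (`COc1ccc(/C=C2\CS(=O)(=O)C/C(=C\c3ccc([N+](=O)[O-])cc3)C2=O)cc1`) has not yet been measured. It differs from compound 2 in one place: methyl in place of hydrogen on an oxygen on an aromatic ring. This turns hydroxy into methoxy, or 4-hydroxyphenyl into 4-methoxyphenyl. Going by the values given here, no measured pair shows this change alone, so the evidence is indirect. Compound 1 also carries 4-methoxyphenyl and gives 3570 nM, so no shift beyond the scatter is expected in this assay. The estimated step, a 1.2-fold higher number from compound 2 to compound 3 (0.08 log units; within the scatter), is expected to remain within the scatter. For compound 3 the expected value is 2600 nM, with an estimated range of 1100 nM to 6000 nM.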

Compound 3, half-maximal inhibitory concentration: 2090 nM
Compound 3: the middle estimate sits 1.2-fold (0.09 log units) above what was measured, within the range that was stated.
By their numbers in this assay, from the lowest: compounds 3, 2 and 1 (each within the scatter of the next).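

In this assay the exchange of hydroxy for methoxy, with methyl in place of hydrogen on an oxygen on an aromatic ring, can now be read alone: it gives a 1.0-fold lower number from compound 2 to compound 3 (0.02 log units; within the scatter) and so does not separate the two compounds. For the compounds shown here, the exchange of methoxy for nitro on an aromatic carbon, also read alone for the first time, gives a 1.7-fold lower number from compound 1 to compound 3 (0.23 log units; within the scatter) and does not separate its two compounds either. Nothing at hand gives a reason for these small steps.

The compounds shown leave open whether a longer chain on this oxygen, such as ethoxy in place of methoxy, would move the number beyond the scatter. Going by these compounds, it also remains open whether an amine or a carboxylic acid in place of nitro on the aromatic carbon would do so.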